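Swapping neopentyl for cyclopropyl on a shared core

The compounds below may be only part of what the source reports. "The series", "measured", "known", "first", "only" and "open" are said of these compounds alone.

The study concerns two measured compounds and one that has not yet been tested. Compound 1 has the structure `CC(C)CCn1nc(C2CCCC2)c(O)c(C2=NS(=O)(=O)c3cc(NS(C)(=O)=O)ccc3N2)c1=O` and compound 2 the structure `CC(C)(C)CCn1nc(-c2cccs2)c(O)c(C2=NS(=O)(=O)c3cc(NS(C)(=O)=O)ccc3N2)c1=O`. Both were examined in an ADME assay on Huh-7 cells (Homo sapiens) for cytotoxicity, with a stated time of 72 h; on this read-out lower numbers stand for higher toxicity in this test and higher numbers for lower toxicity in this test. Compound 1 reaches only a limit of the assay in this assay, reported as > 1000 nM. Compound 2 likewise returns only a limit in this assay, given as > 1000 nM. Taken together, the limit of > 1000 nM in this assay, at which 2 of the 2 values shown sit — neither value is a number, so nothing can be said about any difference between compound 1 and compound 2.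

Compound 3, with the structure `CS(=O)(=O)Nc1ccc2c(c1)S(=O)(=O)N=C(c1c(O)c(-c3cccs3)nn(CC3CC3)c1=O)N2`, differs from compound 2 by cyclopropyl in place of neopentyl on a saturated chain carbon bound to an aromatic nitrogen. Cut one bond further out, the same difference reads 3,3-dimethylbutyl to cyclopropylmethyl. Among the compounds with values here, no step between measured compounds is available, so the expectation rests on compound 2 alone, whose result in this assay is a limit. Compound 3 is therefore expected to sit at or beyond that limit again, with an estimated step that the limit leaves unreadable from compound 2 to compound 3 that amounts to none beyond the scatter. The estimate for compound 3 in this assay is 2000 nM, within a range from 800 nM to 6000 nM.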

Compound 3, half-maximal cytotoxic concentration: > 1000 nM
Compound 3: a limit, no number; the forecaster's own chance of this, stated with the estimate: 80%; the middle value is on the limit's open side.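

In this assay compound 3 gives > 1000 nM, which is a limit and not a number. Within the data shown here, no step can therefore be read between compound 2 and compound 3: the limit of > 1000 nM in this assay, at which 3 of the 3 values shown sit. The compounds shown leave open where the half-maximal cytotoxic concentration of each actually lies, and whether cyclopropyl in place of neopentyl alters it.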